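Bombesin receptor subtype-3 agonists: aryl replacement on the shared core

The source may hold more compounds than are shown below. What is called first, only, known or untested is meant among the compounds shown, and "the series" means these compounds.

Measured so far:
- compound 1, `c1ccc(-c2ccc(CCc3nc(CC4CCCC4)c[nH]3)cc2)nc1`: 22 nM
- compound 2, `CCC(C)(C)Cc1c[nH]c(CCc2ccc(-n3ncnn3)cc2)n1`: 25 nM

Both numbers come from a functional assay on HEK293 cells for agonist activity at Bombesin receptor subtype-3 (Mus musculus), read by luminescence and calcium flux, with a stated time of 10 min; a lower number here means that less compound is needed, a higher number that more compound is needed for the effect. Compound 2 holds the highest of the two numbers in this assay, but its nearest neighbour, compound 1, sits only a little lower, and the gap between them lies within the scatter of repeated measurements; no order can be read from these two values.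

The next compound is compound 3, `CCC(C)(C)Cc1c[nH]c(CCc2ccc(-c3cccc(C)n3)cc2)n1`. It differs from compound 2 in one place: 6-methylpyridin-2-yl in place of 2H-tetrazol-2-yl on an aromatic carbon. The rest of the shared core, including the chain on the other side of it, is unchanged.

Among the measured compounds shown here, no step between two measured compounds describes this exchange, so the expectation rests on the two values alone. Both measured compounds, with different groups at this position, give numbers close to one another in this assay, which suggests the position tolerates variation. The step from compound 2 to compound 3 is therefore expected to be small, a 1.3-fold lower number from compound 2 to compound 3 (0.10 log units; within the scatter), with no direction beyond the scatter. For compound 3 the estimate in this assay is 20 nM, with a range of 6 nM to 65 nM.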

Compound 3, half-maximal effective concentration: 19 nM
Compound 3: middle estimate off by 1.1-fold (0.02 log units), on the high side; measured number inside the range.
By their numbers in this assay, from the lowest: compounds 3, 1 and 2 (each within the scatter of the next).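

In this assay the exchange on this aromatic carbon gives a 1.3-fold lower number from compound 2 to compound 3 (0.12 log units; within the scatter) even though a five-membered aromatic ring with 4 hetero atoms gives way to a six-membered aromatic ring with 1 hetero atom, and 4 hydrogen-bond acceptors give way to 1. Among the compounds shown here, compounds 1 and 2 differ in more than one place, so only this pair shows the position on its own, with the rest of the shared core and the chain on the other side held fixed; at this position, the two groups cannot be told apart by their numbers in this assay. No available measurement bears on why these two groups give numbers within the scatter of each other.

Still open, going by these compounds, is whether the same aromatic carbon accepts groups of another kind, such as a carboxylic acid, a primary amine or a longer alkyl chain, with numbers in this same region. Also open, on these data alone, is whether 6-methylpyridin-2-yl reads the same way on the core of compound 1, which carries a different chain on the other side.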